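The source may hold more compounds than are shown below. What is called first, only, known or untested is meant among the compounds shown, and "the series" means these compounds.

Measured compounds:
compound 1 `N#Cc1ccc(/C=N/NC(=O)Nc2cc3c(Nc4ccc(F)c(Cl)c4)ncnc3cc2O[C@H]2CCOC2)cc1` — 26400 nM
compound 2 `O=C(N/N=C/c1ccc([N+](=O)[O-])cc1)Nc1cc2c(Nc3ccc(F)c(Cl)c3)ncnc2cc1O[C@H]1CCOC1` — 35300 nM

These two compounds were tested in a functional assay on HepG2 cells (Homo sapiens) for cytotoxicity, read by MTT assay, with a stated time of 72 h; on this read-out lower numbers stand for stronger inhibition and higher numbers for weaker inhibition. Compound 1 has the lowest of the two numbers, and compound 2 stands nearest to it: a 1.3-fold higher number from compound 1 to compound 2 (0.13 log units; within the scatter). So the one change seen so far, at the aromatic carbon of the outer ring, did not move the number beyond the scatter.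

Compound 3 `O=C(N/N=C/c1ccc(O)c(Br)c1)Nc1cc2c(Nc3ccc(F)c(Cl)c3)ncnc2cc1O[C@H]1CCOC1` has not yet been tested in this assay. It differs from compound 1 at the same outer ring: 3-bromo-4-hydroxyphenyl in place of 4-cyanophenyl on a carbon with a double bond to nitrogen

Within the data shown here, the only measured step, from compound 1 to compound 2, touched this ring with a different group and stayed within the scatter. It does not directly cover a hydroxy and bromine pair, so the expectation rests on that one step alone. Compound 3 is therefore expected to land close to compound 1, with a 1.2-fold lower number from compound 1 to compound 3 (0.08 log units; within the scatter) amounting to no clear change beyond the scatter. The expected value for compound 3 is 22000 nM, estimated to fall between 8000 nM and 60000 nM.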

Compound 3, half-maximal inhibitory concentration: 660 nM
Beside the measured number, compound 3's estimate is 33-fold (1.52 log units) above it, outside the stated range (below it).
By their numbers in this assay, from the lowest: compound 3; then compounds 1 and 2 (each within the scatter of the next).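

In this assay, the group on the carbon with a double bond to nitrogen turns out to matter a great deal: 3-bromo-4-hydroxyphenyl in place of 4-cyanophenyl gives a 40-fold lower number from compound 1 to compound 3 (1.60 log units; beyond the scatter) and in place of 4-nitrophenyl gives a 53-fold lower number from compound 2 to compound 3 (1.73 log units; beyond the scatter) on the same core. The earlier swap of nitro for cyano stayed within the scatter, so the position only looked indifferent from that single step; it clearly responds to a different ring substitution. Nothing measured here explains why this ring stands so far apart from the other two.

The bromine and the hydroxy arrive together, so the compounds shown cannot say whether one of them or the pair accounts for the step. From the compounds shown here alone, it also remains open how a methoxy in place of the hydroxy, or a chlorine in place of the bromine, would read out here.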